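Replacing 4-methylphenyl with a carbamoylpiperidinylmethyl group

The source may report more compounds than this note shows. Statements on the series, on what has been measured and on what is new or still open speak of the compounds shown alone.

Three compounds were examined in a functional assay on HepG2 cells (Homo sapiens) for cytotoxicity, read by MTT assay, with a stated time of 48 h; a higher number here means a weaker inhibitor, a lower number a stronger inhibitor. Compound 1 `CCC(=O)N1N=C(C)CC1c1cc(Br)ccc1O` gave "not active" (no number reported) and compound 2 `CC1=NN(C(=O)COc2ccc(Cl)cc2)C(c2cc(Br)ccc2O)C1` gave "not active" (no number reported), so neither comes with a number. Among the compounds with values here, compound 3 `Cc1ccc(C(=O)N2N=C(c3cc4ccccc4oc3=O)CC2c2ccccc2)cc1` is the only one with a measured value: in this assay compound 3 gives 52300 nM, a high concentration, which marks it as a weak inhibitor of these cells, and with the other two entries lacking a number there is nothing to rank it against.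

Compound 4 `NC(=O)C1CCN(CC(=O)N2N=C(c3cc4ccccc4oc3=O)CC2c2ccccc2)CC1` differs from compound 3 in one place: (4-carbamoylpiperidin-1-yl)methyl in place of 4-methylphenyl on a carbonyl carbon. Within the data shown here, no pair of measured compounds that differ in a single place is available, so the effect of this kind of change in this assay cannot be read from the data; the rest of compound 3 is kept unchanged. Given the weak starting point, compound 4 is expected to remain in the same weak range, with an expected step of a 1.1-fold higher number from compound 3 to compound 4 (0.06 log units; within the scatter), not beyond the usual scatter. Compound 4 is therefore estimated at 60000 nM in this assay, within a plausible range from 20000 nM to 200000 nM. A fair chance remains that only an inactive result is reported, as happened for compound 1 and compound 2.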

Compound 4, half-maximal inhibitory concentration: 19300 nM
Beside the measured number, compound 4's estimate is 3.1-fold (0.49 log units) above it, and the stated range ends above it.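

Within the data shown here, this is the first measured comparison at this position, the group on a carbonyl carbon whose other neighbour is an amide-type nitrogen in a ring. In this assay, putting (4-carbamoylpiperidin-1-yl)methyl in place of 4-methylphenyl gives a 2.7-fold lower number from compound 3 to compound 4 (0.43 log units; beyond the scatter) and this modest step lies beyond the usual scatter, so the position does respond to what it carries. It also tolerates a large change: a non-aromatic ring with a nitrogen and a carbamoyl group, adding a hydrogen-bond donor and hydrogen-bond acceptors, replaces an all-carbon aromatic ring with no loss of activity against these cells, and no measurement on hand explains the shift.

A single step cannot show which part of the new group matters, since the aromatic ring leaves and the piperidine, the methylene link and the carbamoyl group all enter together. A plain piperidin-1-ylmethyl group, or a carboxylic acid in place of the carbamoyl group, would help separate these parts, and the shift may or may not hold on a different core, such as those of compound 1 and compound 2.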